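The source may report more compounds than this note shows. Statements on the series, on what has been measured and on what is new or still open speak of the compounds shown alone.

Measured so far:
compound 1 `Fc1ccc(/C=N/NC(=S)Nc2cccc3ccccc23)cc1Cl` — 51.3 ug/mL
compound 2 `Fc1cccc(/C=N/NC(=S)Nc2cccc3ccccc23)c1F` — 500 ug/mL
compound 3 `Fc1ccc(Oc2ccc(/C=N/NC(=S)Nc3cccc4ccccc34)cc2)cc1` — 62.5 ug/mL

In a functional assay on A549 cells (Homo sapiens) for cytotoxicity, read by XTT assay, with a stated time of 24 h (on this read-out lower numbers stand for stronger inhibition and higher numbers for weaker inhibition), compound 2 gives the highest number of the three, with compound 3 the nearest and compound 1 the furthest.

Compound 4 `Fc1cccc(Cl)c1/C=N/NC(=S)Nc1cccc2ccccc12` is not yet measured. Its change from compound 2: 2-chloro-6-fluorophenyl in place of 2,3-difluorophenyl on a carbon with a double bond to nitrogen.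

Within the data shown here, one measured step touches the same place: a 9.7-fold higher number from compound 1 to compound 2 (0.99 log units; beyond the scatter). That step exchanged a chlorine-bearing ring for a ring with fluorine only and raised the number; the present change returns a chlorine to the ring, though at a different pattern, so a step downward from compound 2 is expected in this assay, of uncertain size.

Compound 4 is therefore estimated at 150 ug/mL (range 50 ug/mL to 500 ug/mL), an expected step of a 3.3-fold lower number from compound 2 to compound 4 (0.52 log units; beyond the scatter).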

Compound 4, half-maximal inhibitory concentration: 125 ug/mL
Compound 4: middle estimate off by 1.2-fold (0.08 log units), on the high side; the range from low to high includes it.
By their numbers in this assay, from the lowest: compounds 1, 3 and 4 (each within the scatter of the next, the first and the last beyond it); then compound 2.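

In this assay, the 2-chloro-6-fluorophenyl group in place of 2,3-difluorophenyl gives a 4.0-fold lower number from compound 2 to compound 4 (0.60 log units; beyond the scatter), so a ring bearing chlorine recovers part of the rise seen with fluorine alone. Chlorine alone does not settle the number: with the same two halogens on the ring, 2-chloro-6-fluorophenyl in place of 3-chloro-4-fluorophenyl gives a 2.4-fold higher number from compound 1 to compound 4 (0.39 log units; beyond the scatter), so their arrangement matters in this series. No available measurement explains these shifts.

Still open, on these data alone, is whether an amine or a carboxylic acid on this ring would keep the lower numbers, and how a dichlorophenyl group would compare.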